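Heteroaryl exchange at the shared core: expecting compound 4

A few compounds are considered here, and "the series" means these few. Any claim that something is new, unique, unknown or untested is made for them only; others in the source may bear on it.

Three members of the series have been measured in a functional assay on CHO-K1 cells for antagonist activity at adenosine receptor A1 (Homo sapiens), read by a beta-galactosidase reporter and cAMP accumulation, with stated times of 15 min and 6 h; a lower number here means a stronger inhibitor, a higher number a weaker inhibitor. Compound 1 `Nc1nc(-c2cnco2)nc2sc(Cc3ccccc3)cc12` gives 106 nM. Compound 2 `Cc1csc(-c2nc(N)c3cc(Cc4ccccc4Cl)sc3n2)n1` gives 49.6 nM. Compound 3 `Cc1nc(-c2nc(N)c3cc(Cc4ccccc4)sc3n2)cs1` gives 263 nM, the highest of the three numbers. The nearest neighbour is compound 1, connected by a single-change step: a 2.5-fold higher number from compound 1 to compound 3 (0.39 log units; beyond the scatter). Among the compounds with values here, compound 2 sits furthest off; its value and that of compound 3 differ by more than the scatter, but compound 2 also differs from compound 3 elsewhere, so no single-change step joins the two.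

Compound 4 `Nc1nc(-c2ccncc2)nc2sc(Cc3ccccc3)cc12` is the next untested member. It differs from compound 3 in one place: pyridin-4-yl in place of 2-methyl-1,3-thiazol-4-yl on an aromatic carbon. Within the data shown here, the only measured step that bears on this change is the earlier exchange of the aromatic group on the same carbon of the shared core, a 2.5-fold higher number from compound 1 to compound 3 (0.39 log units; beyond the scatter), a modest rise. Compound 4 carries neither group of that pair, so the direction is not fixed by the data; a step of similar size is expected, somewhat more likely downward, as compound 3 stands at 263 nM, the highest value in the set. The expected step is a 1.8-fold lower number from compound 3 to compound 4 (0.24 log units; within the scatter). Compound 4 is estimated at 150 nM, with a range from 50 nM to 450 nM.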

Compound 4, inhibition constant: 812 nM
Beside the measured number, compound 4's estimate is 5.4-fold (0.73 log units) below it, outside the stated range (above it).
By their numbers in this assay, from the lowest: compound 2; then compound 1; then compound 3; then compound 4.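

In this assay, the position between two ring nitrogen atoms tolerates less well the exchange of either five-membered aromatic ring for the six-membered pyridin-4-yl: the rise is a 3.1-fold higher number from compound 3 to compound 4 (0.49 log units; beyond the scatter) against 2-methyl-1,3-thiazol-4-yl and a 7.7-fold higher number from compound 1 to compound 4 (0.88 log units; beyond the scatter) against 1,3-oxazol-5-yl. With only the exchange between the two five-membered rings available before, this position had shown a single modest step; it now has three groups on an otherwise unchanged shared core, and both steps to pyridin-4-yl go the same way, to higher numbers, so the aromatic group at this carbon clearly affects the read-out and the six-membered ring here is the least favoured of the three. No measurement at hand explains this order of the three groups.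

Whether the higher number goes with the six-membered ring as such or with the placing of its ring nitrogen stays open: a pyridin-3-yl or a plain phenyl group at this carbon would separate the two, and the compounds shown include neither. Compound 2 differs from the others in more than one place, so it also leaves open whether the order of these groups holds with a different group elsewhere on the shared core.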